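Adding a second chloro to compound 3

A few compounds are considered here, and "the series" means these few. Any claim that something is new, unique, unknown or untested is made for them only; others in the source may bear on it.

Measured in a functional assay on cells (leukaemia cell line, Homo sapiens) for inhibition, read by sulforhodamine B assay, with a stated time of 48 h; a higher number here means a weaker inhibitor of growth, a lower number a stronger inhibitor of growth:
- compound 1 `O=S(=O)(Nc1ccccc1Cl)c1ccc(-c2cnc(C3CC3)o2)cc1` gives 429 nM
- compound 2 `O=S(=O)(Nc1ccc(Cl)c(F)c1)c1ccc(-c2cnc(C3CC3)o2)cc1` gives 380 nM
- compound 3 `O=S(=O)(Nc1cccc(Cl)c1)c1ccc(-c2cnc(C3CC3)o2)cc1` gives 477 nM

These compounds share a core and differ only in the substituted phenyl group on the sulfonamide nitrogen. Compound 3 (477 nM) lies within the scatter of both other compounds, so the three cannot be ranked. Compound 4 `O=S(=O)(Nc1cc(Cl)ccc1Cl)c1ccc(-c2cnc(C3CC3)o2)cc1` has not yet been measured. It differs from compound 3 by a single change: chloro in place of hydrogen on an aromatic carbon. This is chloro in place of hydrogen on an aromatic carbon, ortho to a large group and para to a chloro group, turning 3-chlorophenyl into 2,5-dichlorophenyl.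

For the measured compounds named here, no measured compound carries this exact group, so the best guide is how little the value has moved when this phenyl group was altered. The measured steps are small: a 1.1-fold higher number from compound 1 to compound 3 (0.05 log units; within the scatter), a 1.3-fold higher number from compound 2 to compound 3 (0.10 log units; within the scatter) and a 1.1-fold lower number from compound 1 to compound 2 (0.05 log units; within the scatter). Going by the values given here, with only three compounds, this is thin evidence, but it gives no reason to expect a large shift. The expected change is no larger than the scatter, and the estimated step is a 1.2-fold lower number from compound 3 to compound 4 (0.08 log units; within the scatter). Compound 4 is estimated at 400 nM, with an expected range from 200 nM to 800 nM in this assay.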

Compound 4, concentration for 50% growth inhibition: 1020 nM
Estimate against measurement, compound 4: 2.6-fold (0.41 log units) below, outside the stated range (above it).
By their numbers in this assay, from the lowest: compounds 2, 1 and 3 (each within the scatter of the next); then compound 4.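

In this assay, for the compounds shown here, changes to the phenyl group on the sulfonamide nitrogen had so far stayed within the scatter, but 2,5-dichlorophenyl is the first group to move the number beyond it: the added chloro gives a 2.1-fold higher number from compound 3 to compound 4 (0.33 log units; beyond the scatter), and the second chloro added to the other single-chloro compound gives a 2.4-fold higher number from compound 1 to compound 4 (0.38 log units; beyond the scatter), so either route to this group yields a weaker inhibitor of growth. Carrying two halogens on the ring is not enough on its own to explain this, and compound 2 goes against such a rule: its 4-chloro-3-fluorophenyl group shows no such rise against the single-chloro compounds, and the change to 2,5-dichlorophenyl gives a 2.7-fold higher number from compound 2 to compound 4 (0.43 log units; beyond the scatter). Nothing measured here accounts for the rise.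

The compounds shown leave open whether the rise belongs to chloro specifically or to any group at these two places on the ring, such as a methyl, a methoxy or a nitrile in place of either chloro. They also leave open how an amine or a carboxylic acid on this ring would fare in this assay.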